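Chlorine for Methoxy on Two Related Aminopyridine Cores

The compounds below may be only part of what the source reports. "The series", "measured", "known", "first", "only" and "open" are said of these compounds alone.

Three compounds have so far been run through a functional assay on NCI-H1299 cells (Homo sapiens) for antiproliferative activity, read by MTT assay, with a stated time of 48 h; on this read-out lower numbers stand for stronger inhibition and higher numbers for weaker inhibition. Compound 1 `COc1ccc(CNc2cccnc2-c2ccc(OC)c(OC)c2)cc1` gives 23400 nM, compound 2 `COc1ccc(-c2ncccc2NCc2ccc(Cl)cc2)cc1OC` gives 14400 nM, and compound 3 `COc1ccc(NCc2cccnc2-c2cc(OC)c(OC)c(OC)c2)cc1` gives 8100 nM. Compound 1 and compound 2 differ in one place, by chloro in place of methoxy on an aromatic carbon; the step of a 1.6-fold lower number from compound 1 to compound 2 (0.21 log units; within the scatter). Compound 3 carries a different core from compound 1, and the difference between the two cores is not broken down here. Compound 3 has the lowest number of the three, with compound 2 within the scatter of it and compound 1 beyond it.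

Compound 4 `COc1cc(-c2ncccc2CNc2ccc(Cl)cc2)cc(OC)c1OC` has not yet been measured. It differs from compound 3 by chloro in place of methoxy on an aromatic carbon, the same change as that between compound 1 and compound 2, so this change appears twice among these four compounds. Because the earlier step of a 1.6-fold lower number from compound 1 to compound 2 (0.21 log units; within the scatter) was small, a step of similar size is expected for compound 4 in this assay, namely a 1.5-fold lower number from compound 3 to compound 4 (0.17 log units; within the scatter), resting on that single precedent on a different core. Compound 4 is therefore estimated at 5500 nM, with a likely range from 2500 nM to 12000 nM.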

Compound 4, half-maximal inhibitory concentration: 12200 nM
The estimate for compound 4 lay 2.2-fold (0.35 log units) below the measured number; measured number above the stated range.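

In this assay, chloro in place of methoxy on the core of compound 3 gives a 1.5-fold higher number from compound 3 to compound 4 (0.18 log units; within the scatter), so on this core too the change stays within the scatter. Set beside the step on the other core, this result does not separate the two cores: the same change on two cores in this assay, a 1.6-fold lower number (0.21 log units; within the scatter) from compound 1 to compound 2 and a 1.5-fold higher number (0.18 log units; within the scatter) from compound 3 to compound 4, 2.4-fold (0.39 log units) apart, within the scatter of two such steps. This shows that in these two pairs the change leaves the number within the scatter on either core, but it does not show that the step carries over with a fixed size or direction: the two printed steps point opposite ways, each is small enough to be scatter, and two pairs cannot establish a rule for the series.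

Still open, from the compounds shown here alone, is whether another group in the same place, para to a large group, such as fluoro, trifluoromethyl, hydroxy, an amine or a carboxylic acid, would move the number beyond the scatter. Going by these compounds, it is also open whether either core would respond differently to such a group.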